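The source may hold more compounds than are shown below. What is called first, only, known or untested is meant among the compounds shown, and "the series" means these compounds.

Measured so far:
compound 1, `Cc1cc(Cl)cc(-c2ccnc3cc(CN4C(=O)C5C(C4=O)C5(C)C)sc23)c1CC1CCCNC1`: 1.3 nM
compound 2, `Cc1cc(Cl)cc(-c2ccnc3cc(CN4C(=O)C5CC5C4=O)sc23)c1C[C@H]1OCCN[C@@H]1C`: 1.5 nM

In an assay on isolated protein for inhibition of ubiquitin carboxyl-terminal hydrolase 7 (Homo sapiens), read by fluorescence, with stated times of 30 min and 1 h (a higher number here means a weaker inhibitor, a lower number a stronger inhibitor), compound 1 gives 1.3 nM and compound 2 gives 1.5 nM. Compound 1 has the lower of the two numbers, yet the gap to compound 2 lies within the scatter of the assay, so the two cannot be told apart. Within the data shown here, the two compounds also differ in more than one place, so no single step between them can be read off.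

Compound 3, `Cc1cc(Cl)cc(-c2ccnc3cc(CN4C(=O)C5C(C4=O)C5(C)C)sc23)c1OC1CCCNC1`, differs from compound 1 in one place: (piperidin-3-yl)oxy in place of (piperidin-3-yl)methyl on an aromatic carbon. Both measured compounds sit at the strong end of this assay, and nothing measured here shows how such an exchange plays out. The step of a 2.3-fold higher number from compound 1 to compound 3 (0.36 log units; beyond the scatter) is therefore expected to be small, at most a mild weakening, and may not rise beyond the scatter. Compound 3 is expected to give about 3 nM, with a plausible range from 0.8 nM to 12 nM.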

Compound 3, half-maximal inhibitory concentration: 2.4 nM
The estimate for compound 3 lay 1.3-fold (0.10 log units) above the measured number; measured number inside the range.
By their numbers in this assay, from the lowest: compounds 1, 2 and 3 (each within the scatter of the next).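

In this assay, (piperidin-3-yl)oxy in place of (piperidin-3-yl)methyl on this aromatic carbon gives a 1.8-fold higher number from compound 1 to compound 3 (0.27 log units; within the scatter), so the oxygen-linked and carbon-linked groups cannot be told apart here. At this position, ortho to a large group and ortho to a methyl group, the entering group has 2 hydrogen-bond acceptors where the leaving group has 1, and the number stays at the strong end of the assay. No measurement at hand offers a reason for this outcome.

As far as these compounds go, how a nitrogen link, as in (piperidin-3-yl)amino, or a longer chain, as in 2-(piperidin-3-yl)ethyl, would fare on this carbon remains open. So does whether the same exchange would read alike on compound 2, which differs from compound 1 in more than one place.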